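A few compounds are considered here, and "the series" means these few. Any claim that something is new, unique, unknown or untested is made for them only; others in the source may bear on it.

Measured so far in an assay on HeLa cells for inhibition of Deoxyuridine 5'-triphosphate nucleotidohydrolase, mitochondrial (Homo sapiens), read by crystal violet staining, with a stated time of 24 h; on this read-out higher numbers stand for an effect only at larger amounts of compound and lower numbers for an effect already at smaller amounts: compound 1 `CC(C)(NS(=O)(=O)c1cccc(OCC(F)F)c1)c1ccc(Cn2ccc(=O)[nH]c2=O)cc1` with 100 nM; compound 2 `C[C@@H](NS(=O)(=O)c1ccc(Cn2ccc(=O)[nH]c2=O)cc1)c1cccc(OCC2CC2)c1` with 930 nM; compound 3 `C[C@@H](NS(=O)(=O)c1ccc(Cn2ccc(=O)[nH]c2=O)cc1)c1cccc(OC2CCCC2)c1` with 610 nM.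

Compound 3 stands second highest of the three numbers in this assay. Among the compounds with values here, its nearest neighbour is compound 2, whose number is within the scatter of it; the only single-point step among the measured compounds, a 1.5-fold lower number from compound 2 to compound 3 (0.18 log units; within the scatter), is therefore not a change worth reading. Within the data shown here, the furthest is compound 1, whose number lies well below that of compound 3, beyond the scatter; compound 1 differs from compound 3 in more than one place, so no step is drawn between them.

Compound 4 `C[C@@H](NS(=O)(=O)c1ccc(Cn2ccc(=O)[nH]c2=O)cc1)c1cccc(OCC(F)F)c1` is not yet measured. It differs from compound 3 in one place: 2,2-difluoroethyl in place of cyclopentyl on an oxygen on an aromatic ring. Among the measured compounds shown here, no measured step covers this exact exchange on the shared core of compound 3. For the measured compounds named here, the one step that exists on this oxygen, from compound 2 to compound 3, was within the scatter, which gives no ground for expecting a large shift in this assay here either. Compound 1 carries the same 2,2-difluoroethyl on an oxygen on an aromatic ring, but on a different arrangement of the core, so its number cannot be carried over.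

For compound 4 the number in this assay is expected at 500 nM, with a range from 150 nM to 1600 nM. The expected step is a 1.2-fold lower number from compound 3 to compound 4 (0.09 log units; within the scatter), that is, none beyond the scatter.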

Compound 4, half-maximal effective concentration: 610 nM
For compound 4 the middle estimate is 1.2-fold (0.09 log units) below the measured one; the range from low to high includes it.
By their numbers in this assay, from the lowest: compound 1; then compounds 3, 4 and 2 (each within the scatter of the next).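

On the shared core, 2,2-difluoroethyl in place of cyclopentyl on an oxygen on an aromatic ring gives no change at the digits printed from compound 3 to compound 4 (within the scatter) in this assay, so a group with no ring and with fluorine reads the same here as a five-membered carbon ring. Difluoromethyl in place of cyclopropyl on a saturated chain carbon bound to that oxygen gives a 1.5-fold lower number from compound 2 to compound 4 (0.18 log units; within the scatter), which means cyclopropylmethyl, cyclopentyl and 2,2-difluoroethyl cannot be told apart at this place on this core in this assay. No evidence on hand bears on why these groups read alike.

From the compounds shown here alone, it remains open whether this flat reading holds for groups of another kind on this oxygen, such as a chain ending in an amine or a carboxylic acid, or a longer chain such as n-hexyl. Also open is what lies behind the number of compound 1 at 100 nM, since that compound carries 2,2-difluoroethyl but differs from compound 4 in more than one place and so offers no step to read.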